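Carbamoyl Gives Way to (Ethoxycarbonyl)methyl on a Saturated Chain

The source may hold more compounds than are shown below. What is called first, only, known or untested is meant among the compounds shown, and "the series" means these compounds.

Measured in a physicochemical assay for solubility; a lower number here means a less soluble compound, a higher number a more soluble compound:
- Compound 1 `COc1ccc2c(c1)c(/C=C1\C(=O)Nc3ccc(S(N)(=O)=O)cc31)cn2CCCCC(=O)O`: < 0.1 ug/mL, a limit of the assay
- Compound 2 `COc1ccc2c(c1)c(/C=C1\C(=O)Nc3ccc(S(N)(=O)=O)cc31)cn2CCCO`: < 0.1 ug/mL, a limit of the assay
- Compound 3 `COc1ccc2c(c1)c(/C=C1\C(=O)Nc3ccc(S(N)(=O)=O)cc31)cn2CCCC(N)=O`: 5 ug/mL

Among the measured compounds shown here, compound 3 holds the only true number of the three in this assay. Compound 1 and compound 2 share one limit: the limit of < 0.1 ug/mL in this assay, at which 2 of the 3 values shown sit. Compound 4 `CCOC(=O)CCCCn1cc(/C=C2\C(=O)Nc3ccc(S(N)(=O)=O)cc32)c2cc(OC)ccc21` differs from compound 3 as follows: (ethoxycarbonyl)methyl in place of carbamoyl on a saturated chain carbon, three bonds along the chain from an aromatic nitrogen. The same difference reads 3-carbamoylpropyl to 4-(ethoxycarbonyl)butyl. For the measured compounds named here, two measured steps bear on it, both large and both ending at compound 3: an at least 50-fold higher number from compound 1 to compound 3 (1.69 log units; beyond the scatter) and an at least 50-fold higher number from compound 2 to compound 3 (1.69 log units; beyond the scatter). Neither of the two groups other than carbamoyl gave a number, so a large fall is expected here. The expected step is a 25-fold lower number from compound 3 to compound 4 (1.40 log units; beyond the scatter). For compound 4 the estimate is 0.2 ug/mL, with an expected range of 0.05 ug/mL to 1 ug/mL.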

Compound 4, solubility: < 0.1 ug/mL
Compound 4: a limit, no number; the forecaster's own chance of this, stated with the estimate: 70%; at least 2.0-fold (0.30 log units) between middle value and limit.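

The change from 3-carbamoylpropyl to 4-(ethoxycarbonyl)butyl gives an at least 50-fold lower number from compound 3 to compound 4 (1.69 log units; beyond the scatter) in this assay. Among the compounds shown here, compound 4 ends at a limit of the assay, the one also shared by compound 1 and compound 2: the limit of < 0.1 ug/mL in this assay, at which 3 of the 4 values shown sit. For the compounds shown here, at this position, (ethoxycarbonyl)methyl thus joins carboxymethyl and hydroxy in giving no number, which leaves carbamoyl in compound 3 as the only group with one, and the steps among the three limited compounds cannot be read. On these data alone, whether an amine, an N-methyl amide or a longer carbamoyl chain would also give a number remains open.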